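Removing a Methyl from an Oxygen: Expecting Compound 3

A few compounds are considered here, and "the series" means these few. Any claim that something is new, unique, unknown or untested is made for them only; others in the source may bear on it.

Of the compounds shown here, two have been measured so far. Compound 1 `Cc1cc(O)cc(-c2nn(CC#N)cc2-c2ccnc(-c3ccc(Oc4ccccc4)cc3)c2)c1` carries a hydroxy group and a phenoxy-substituted ring; in a functional assay on OVCAR-3 cells (Homo sapiens) for cytotoxicity, read by sulforhodamine B assay, with a stated time of 48 h, tested at 100 nM (a lower number here means a stronger effect, a higher number a weaker effect of the compound at the concentration tested), compound 1 gives 93%. Compound 2 `COc1cc(C)cc(-c2nn(CC#N)cc2-c2ccnc(-c3ccc(N(C)C)cc3)c2)c1` carries a methoxy group and a dimethylamino-substituted ring; in this assay compound 2 gives -51%, the lowest of the two numbers and far beyond the scatter from compound 1, which means a much stronger effect on the cells at this concentration. Compound 2 and compound 1 differ in two places, so their values alone do not show which part matters.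

Compound 3 `Cc1cc(O)cc(-c2nn(CC#N)cc2-c2ccnc(-c3ccc(N(C)C)cc3)c2)c1` has not yet been measured in this assay. Relative to compound 2 the change is hydrogen in place of methyl on an oxygen on an aromatic ring. Among the measured compounds shown here, no measured pair shows this single change, so its size is unknown here. For the measured compounds named here, since compound 1, the only compound with a hydroxy group, shows a weak effect, compound 3 is expected to land somewhat higher than compound 2, with a step from compound 2 to compound 3 of a number 51 percentage points higher from compound 2 to compound 3 (beyond the scatter). Compound 3 is estimated at 0%, within a wide range from -55% to 70%.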

Compound 3, a percentage reported as activity, at one concentration (the size of the read-out at that concentration, not a potency): 85%
Compound 3: the middle estimate sits 85 percentage points below what was measured; measured number above the stated range.
By their numbers in this assay, from the lowest: compound 2; then compounds 3 and 1 (each within the scatter of the next).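

In this assay, the step from methoxy to hydroxy on the 3-methoxy-5-methylphenyl ring is a number 136 percentage points higher from compound 2 to compound 3 (beyond the scatter) and everything else in the two structures stays the same, so this one change on the oxygen is enough to take away most of the effect on the cells, something the two earlier compounds, which differ in two places, could not show. Among the compounds shown here, with the hydroxy group in place, the change of dimethylamino in place of phenoxy on an aromatic carbon gives a number 8 percentage points lower from compound 1 to compound 3 (within the scatter) and so cannot be told apart from no change, which places the large difference between the first two compounds at the oxygen in this comparison. Nothing available here explains why removing this methyl matters so much.

The compounds shown leave open whether the methoxy group would give the same large step with phenoxy on the other ring, since the strong effect is seen only for the pairing of methoxy with dimethylamino. They also leave open how much of the oxygen substituent is needed, as a longer chain such as ethoxy or an amine in place of the oxygen group would test how narrow this requirement is.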